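Sulfonyl-bridged series: carbamate to sulfonamide on the fused ring

The source may hold more compounds than are shown below. What is called first, only, known or untested is meant among the compounds shown, and "the series" means these compounds.

Measured so far:
compound 1 `CCCC[C@]1(CC)CS(=O)(=O)c2ccc(Br)cc2[C@@H](c2cccc(OC)c2)[C@H]1O` gives 70 nM in an assay on cells for inhibition of ileal sodium/bile acid cotransporter (Homo sapiens); on this read-out higher numbers stand for weaker inhibition and lower numbers for stronger inhibition
compound 2 `CCCC[C@]1(CC)CS(=O)(=O)c2ccc(N(O)C(=O)OC(C)(C)C)cc2[C@@H](c2ccccc2)[C@H]1O` gives 2670 nM in this assay

Among the measured compounds shown here, compound 2 carries the higher of the two numbers in this assay; its only neighbour is compound 1, whose number lies lower by a margin well beyond the usual scatter. For the measured compounds named here, the two compounds differ from each other at more than one place, so nothing is isolated between them: the values show only that compound 1 is the stronger inhibitor of this pair.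

Compound 3 `CCCC[C@]1(CC)CS(=O)(=O)c2ccc(NS(C)(=O)=O)cc2[C@@H](c2ccccc2)[C@H]1O` is not yet measured. It differs from compound 2 in one place: methanesulfonamido in place of hydroxy(tert-butoxycarbonyl)amino on an aromatic carbon. Going by the values given here, no measured pair in the set isolates this change, so the size of the step rests on judgement alone. The expectation is a move toward stronger inhibition, larger than the scatter but short of the gap that separates compound 2 from compound 1; the expected step is an 8.9-fold lower number from compound 2 to compound 3 (0.95 log units; beyond the scatter). For compound 3 the estimated value in this assay is 300 nM, with a range from 60 nM to 1500 nM.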

Compound 3, half-maximal inhibitory concentration: 600 nM
Compound 3: the middle estimate sits 2.0-fold (0.30 log units) below what was measured; the range from low to high includes it.
By their numbers in this assay, from the lowest: compound 1; then compound 3; then compound 2.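

Among the compounds shown here, the aromatic carbon para to a fused ring responds to the substituent it carries: in this assay, replacing hydroxy(tert-butoxycarbonyl)amino with methanesulfonamido gives a 4.5-fold lower number from compound 2 to compound 3 (0.65 log units; beyond the scatter), the first step that isolates a single change. A carbamate is therefore not required at this position for inhibition, and a sulfonamide linkage is accepted there, with compound 3 at 600 nM. The entering group has 5 heavy atoms against 9 for the leaving group, and each has 1 hydrogen-bond donor, but no measurement available here ties the step to any feature of either group.

The compounds shown leave open how an amine, an acetamido group or a longer ethanesulfonamido chain would read at this aromatic carbon, and whether the hydroxy on the nitrogen or the tert-butoxycarbonyl part of the leaving group accounts for more of the step. Bromine and methanesulfonamido also remain unranked at this position, as compound 1 and compound 3 differ in more than one place and no single-change pair connects them.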